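The source may hold more compounds than are shown below. What is called first, only, known or untested is meant among the compounds shown, and "the series" means these compounds.

Of the compounds shown here, three built on one shared core have been measured in a functional assay on A-375 cells (Homo sapiens) for antiproliferative activity, read by MTT assay, with a stated time of 24 h; on this read-out higher numbers stand for weaker inhibition and lower numbers for stronger inhibition. Compound 1 `COc1cc(OC)c(-c2coc3cc(OCC=C(C)C)ccc3c2=O)cc1OC` gives 1580 nM in this assay, the highest of the three numbers, although all three lie within the usual scatter of one another: compound 2 `COc1cc(OC)c(-c2coc3cc(OCc4ccc(Br)cc4)ccc3c2=O)cc1OC` gives 1000 nM and compound 3 `COc1cc(OC)c(-c2coc3cc(OCc4ccc(C#N)cc4)ccc3c2=O)cc1OC` gives 1550 nM. The step of a 1.6-fold lower number from compound 1 to compound 2 (0.20 log units; within the scatter) and the step of a 1.0-fold lower number from compound 1 to compound 3 (0.01 log units; within the scatter) each swap the same chain for a substituted phenyl on the saturated chain carbon bound to an oxygen on the aromatic ring, and neither moves the number beyond the scatter; the step of a 1.6-fold higher number from compound 2 to compound 3 (0.19 log units; within the scatter) is likewise small.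

Compound 4 `COc1cc(OC)c(-c2coc3cc(OCc4cccc(Cl)c4)ccc3c2=O)cc1OC` has not yet been measured. It differs from compound 1 in one place: 3-chlorophenyl in place of 2-methylprop-1-en-1-yl on a saturated chain carbon bound to an oxygen on an aromatic ring. This change is of the same kind as the two already seen, a substituted phenyl entering where the 2-methylprop-1-en-1-yl group leaves, here carrying a chlorine rather than a bromine or a nitrile. Since the step of a 1.6-fold lower number from compound 1 to compound 2 (0.20 log units; within the scatter) and the step of a 1.0-fold lower number from compound 1 to compound 3 (0.01 log units; within the scatter) both stayed within the scatter, the step of a 1.3-fold lower number from compound 1 to compound 4 (0.10 log units; within the scatter) is expected to be small as well, with no confident direction. Compound 4 is therefore estimated at 1250 nM, with a range from 600 nM to 2600 nM.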

Compound 4, half-maximal inhibitory concentration: 980 nM
For compound 4 the middle estimate is 1.3-fold (0.11 log units) above the measured one; low and high end bracket the measured number.
By their numbers in this assay, from the lowest: compounds 4, 2, 3 and 1 (each within the scatter of the next).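

In this assay, the step of a 1.6-fold lower number from compound 1 to compound 4 (0.21 log units; within the scatter) makes 3-chlorophenyl the third substituted phenyl group at this place, on the saturated chain carbon bound to an oxygen on the aromatic ring, and again the number stays within the scatter. Going by these compounds alone, the new compound also allows a first comparison of a phenyl group whose substituent sits elsewhere on the ring: the step of a 1.6-fold lower number from compound 3 to compound 4 (0.20 log units; within the scatter) and the step of a 1.0-fold lower number from compound 2 to compound 4 (0.01 log units; within the scatter) are both within the scatter, even though 3-chlorophenyl differs from 4-bromophenyl in both the halogen and where it sits. Nothing measured here explains why these exchanges leave the number so little changed.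

The compounds shown leave open whether the number would stay within the scatter with a group of a different kind at this place, such as an amine, a carboxylic acid or a longer chain. They also leave open what a phenyl ring without a substituent would give, and whether chlorine and bromine would match if each sat at the same place on the ring.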